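The compounds below may be only part of what the source reports. "The series", "measured", "known", "first", "only" and "open" are said of these compounds alone.

Measured compounds:
compound 1 `C[C@H]1[C@H](NCc2ccc(C(C)(C)C)s2)C[C@H]2C[C@@H]1C2(C)C` gives 780 nM in an ADME assay on MDCK cells (Canis lupus familiaris) for cytotoxicity, read by microscopy, with a stated time of 48 h; on this read-out higher numbers stand for lower toxicity in this test and lower numbers for higher toxicity in this test;
compound 2 `C[C@H]1[C@H](NCc2cncs2)C[C@H]2C[C@@H]1C2(C)C` gives > 100000 nM in this assay.

The value for compound 2 is a limit of this assay, not a number: compound 2 sits at the limit of > 100000 nM in this assay, at which 1 of the 2 values shown sits. Compound 1 gives a number below that limit. For the measured compounds named here, no step between measured compounds is available here, so the two values can only be compared as they stand.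

Compound 3 `Cc1ccc(CN[C@@H]2C[C@H]3C[C@@H]([C@H]2C)C3(C)C)s1` is not yet measured in this assay. It differs from compound 2 in one place, (5-methylthiophen-2-yl in place of 1,3-thiazol-5-yl on a saturated chain carbon bound to an amine nitrogen). The change brings compound 3 closer in shape to compound 1, which has a larger group on the same ring type. Compound 3 is therefore expected to move from the limit toward a lower number than compound 2, a step estimated as an at least 5.0-fold lower number from compound 2 to compound 3 (0.69 log units; beyond the scatter), though not all the way to the value of compound 1. The estimate for compound 3 in this assay is 20000 nM, within a range from 3000 nM to 100000 nM.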

Compound 3, minimum cytotoxic concentration: 780 nM
Compound 3: middle estimate off by 26-fold (1.41 log units), on the high side; the whole stated range lies above it.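

Replacing 1,3-thiazol-5-yl with 5-methylthiophen-2-yl on a saturated chain carbon bound to an amine nitrogen gives an at least 120-fold lower number from compound 2 to compound 3 (2.10 log units; beyond the scatter) in this assay, so this place has a strong hold on the read-out. Methyl in place of tert-butyl on an aromatic carbon gives no change at the digits printed from compound 1 to compound 3 (within the scatter), so tert-butyl is not required for the higher toxicity in this test seen with compound 1. Compound 2 gives a limit of the assay and not a number, so the step from it gives only a minimum size: the limit of > 100000 nM in this assay, at which 1 of the 3 values shown sits.

The compounds shown do not tell whether the step comes from the change of ring or from its methyl, which an unsubstituted thiophen-2-yl or a methyl-bearing 1,3-thiazol-5-yl would separate. Going by these compounds, how an amine or a carboxylic acid on the ring at this place would read also remains open.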